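A few compounds are considered here, and "the series" means these few. Any claim that something is new, unique, unknown or untested is made for them only; others in the source may bear on it.

In a physicochemical assay for solubility (on this read-out higher numbers stand for higher solubility and lower numbers for lower solubility), compound 1 `CS(=O)(=O)c1ccc(-n2nc(C(F)(F)F)cc2NC2CCC2)nc1` is recorded as "not determined" (no result reported) and compound 2 `CC(C)(C)CNc1cc(C(F)(F)F)nn1-c1ccc(S(C)(=O)=O)cn1` as "not determined" (no result reported). Within the data shown here, that leaves compound 3 `CC(C)COc1cc(C(F)(F)F)nn1-c1ccc(S(C)(=O)=O)cn1`, at 50 ug/mL, as the only number available, with nothing to rank it against. Compound 4 `CC(C)(C)COc1cc(C(F)(F)F)nn1-c1ccc(S(C)(=O)=O)cn1` differs from compound 3 by one change, (methyl in place of hydrogen on a saturated chain carbon bound to three saturated chain carbons), which turns isobutoxy into neopentyloxy. Among the measured compounds shown here, no measured pair shows this change, so the only anchor for a prediction is compound 3 at 50 ug/mL. In this assay, a modest downward move is expected, possibly no larger than the usual scatter, and the estimated step of a 1.7-fold lower number from compound 3 to compound 4 (0.22 log units; within the scatter) reflects that. The expected value for compound 4 is 30 ug/mL, with an estimated range from 10 ug/mL to 80 ug/mL.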

Compound 4, solubility: 100 ug/mL
Estimate against measurement, compound 4: 3.3-fold (0.52 log units) below; measured number above the stated range.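

In this assay, among these compounds, the first measured pair at this position gives a 2.0-fold higher number from compound 3 to compound 4 (0.30 log units; within the scatter), so turning isobutoxy into neopentyloxy leaves the two compounds inside the normal spread of repeat measurements. Adding a methyl on a saturated chain carbon bound to three saturated chain carbons therefore produces no readable change in this single pair. Nothing measured here offers an explanation for the result. The compounds shown leave open how a longer chain, or a carboxylic acid on the chain, would read in this assay at this same position.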